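The source may hold more compounds than are shown below. What is called first, only, known or untested is meant among the compounds shown, and "the series" means these compounds.

In a functional assay on HCT-116 cells (Homo sapiens) for antiproliferative activity, read by MTT assay, with a stated time of 48 h (on this read-out higher numbers stand for weaker inhibition and lower numbers for stronger inhibition), compound 1 (`CCC(CCO)n1cnc2c(Cl)ncnc21`) gives > 50000 nM, which is a limit of the assay and not a number. Compound 2 (`CCCC(CCO)n1cnc2c(Cl)ncnc21`) gives > 50000 nM, again a limit. Compound 3 (`CCCCCC(CCO)n1cnc2c(Cl)ncnc21`) gives > 50000 nM, also a limit. For the measured compounds named here, it therefore stands with the others, and the series so far offers only (the limit of > 50000 nM in this assay, at which 3 of the 3 values shown sit).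

Compound 4 (`CCCCCCC(CCO)n1cnc2c(Cl)ncnc21`) differs from compound 3 by one change: methyl in place of hydrogen on a saturated chain carbon, six bonds along the chain from an aromatic nitrogen. The bearing steps are the earlier changes on the same chain: a step that the two limits leave unreadable from compound 1 to compound 2, a step that the two limits leave unreadable from compound 1 to compound 3 and a step that the two limits leave unreadable from compound 2 to compound 3. None of them has a size that can be read, so they offer no size to carry forward and no direction of change. No step beyond the scatter is therefore expected in this assay, although a step hidden behind the limit cannot be ruled out. The expected change is a number no higher from compound 3 to compound 4 (the limit leaves the size open). For compound 4 the estimated value is 50000 nM, with an expected range from 20000 nM to 100000 nM.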

Compound 4, half-maximal inhibitory concentration: 11900 nM
For compound 4 the middle estimate is 4.2-fold (0.62 log units) above the measured one; measured number outside the range, below it.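

In this assay, for the compounds shown here, the methyl added six bonds along the chain from an aromatic nitrogen gives an at least 4.2-fold lower number from compound 3 to compound 4 (0.62 log units; beyond the scatter), the first step with a readable direction. Set against the shorter chains, compound 4 also gives an at least 4.2-fold lower number from compound 2 to compound 4 (0.62 log units; beyond the scatter) and an at least 4.2-fold lower number from compound 1 to compound 4 (0.62 log units; beyond the scatter), so among these four compounds the number falls only with this last extension of the chain. Each of these sizes is only a minimum, because the other three compounds remain at a limit: the limit of > 50000 nM in this assay, at which 3 of the 4 values shown sit.

The compounds shown leave open whether a longer chain would lower the number further, or whether the trend would stop or reverse. They also leave open whether the step would hold if an amine or a carboxylic acid replaced the hydroxyl at the end of the chain.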